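The source may hold more compounds than are shown below. What is called first, only, known or untested is meant among the compounds shown, and "the series" means these compounds.

Compound 1 `COc1ccc2c(c1)C(=O)C=CC2=O`: 33900 nM
Compound 2 `O=C1C=C(Oc2ccco2)C(=O)c2ccccc21`: 53400 nM
Compound 3 `Cc1ccc(S(=O)(=O)Oc2ccc3c(c2)C(=O)C=CC3=O)cc1`: 16400 nM

These three compounds share a core and have been tested in a functional assay on KB cells (Homo sapiens) for cytotoxicity; on this read-out lower numbers stand for stronger inhibition and higher numbers for weaker inhibition. Among them compound 3 has the lowest number, and both its neighbours lie beyond the usual scatter: compound 1 gives a higher number, and compound 2 a higher one still. Compound 3 is thus the most potent of the three shown here.

Compound 4 `CS(=O)(=O)Oc1ccc2c(c1)C(=O)C=CC2=O` has not yet been measured in this assay. It differs from compound 3 in one place: methyl in place of 4-methylphenyl on a sulfonyl sulfur. Within the data shown here, no two of the measured compounds differ in a single place, so no measured step shows how such a change moves the number in this assay. A small step toward a higher number seems most likely, but one that could stay within the scatter. The step from compound 3 to compound 4 is expected to be a 1.5-fold higher number from compound 3 to compound 4 (0.18 log units; within the scatter). For compound 4 the estimate in this assay is 25000 nM, with a range from 8000 nM to 70000 nM.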

Compound 4, half-maximal inhibitory concentration: 11600 nM
The estimate for compound 4 lay 2.2-fold (0.33 log units) above the measured number; measured number inside the range.
By their numbers in this assay, from the lowest: compounds 4 and 3 (each within the scatter of the next); then compounds 1 and 2 (each within the scatter of the next).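

Swapping the 4-methylphenyl on the sulfonyl sulfur for methyl takes away an entire aromatic ring, yet in this assay the step stays within the usual scatter (a 1.4-fold lower number from compound 3 to compound 4 (0.15 log units; within the scatter)), so at this place the two groups cannot be told apart. The group on the oxygen on the aromatic ring does matter: methylsulfonyl in place of methyl gives a modest step beyond the scatter (a 2.9-fold lower number from compound 1 to compound 4 (0.47 log units; beyond the scatter)), the first measured sign that a change at this oxygen can move the number. No independent measurement here accounts for either step.

Still open, as far as these compounds go, is how other groups on the sulfonyl sulfur, such as an amine or a longer carbon chain, would read in this assay. Also open, from the compounds shown here alone, is whether a carboxylic acid carried on the 4-methylphenyl ring would leave the number unchanged.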